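Series notes: amide substituent change, compound 2 to compound 3

The source may hold more compounds than are shown below. What is called first, only, known or untested is meant among the compounds shown, and "the series" means these compounds.

Measured so far:
- compound 1, `CN(C)S(=O)(=O)c1ccccc1Nc1cc(-c2ccc3ccn(C)c3c2)c2nccnc2c1`: 94 nM in an assay for inhibition of 6-phosphofructo-2-kinase/fructose-2,6-bisphosphatase 3 (Homo sapiens), read by ADP-Glo, with a stated time of 2 h; on this read-out higher numbers stand for weaker inhibition and lower numbers for stronger inhibition
- compound 2, `CN1CCC(NC(=O)c2ccncc2Nc2cc(-c3ccc4ccn(C)c4c3)c3nccnc3c2)CC1=O`: 41 nM in this assay

Compound 2 gives the lowest of the two numbers in this assay. Its nearest neighbour is compound 1, whose value of 94 nM is the higher one, and the gap between the two lies beyond the usual scatter of repeated measurements. Within the data shown here, the two compounds differ in more than one place, so no single step between them can be read off; only their two values are known.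

Compound 3, `CN1CCC(CNC(=O)c2ccncc2Nc2cc(-c3ccc4ccn(C)c4c3)c3nccnc3c2)C1`, has not yet been measured. It differs from compound 2 in one place: (1-methylpyrrolidin-3-yl)methyl in place of 1-methyl-2-oxopiperidin-4-yl on an amide-type nitrogen. Among the measured compounds shown here, no measured pair shows this change, so the expectation rests on compound 2 alone and on the change itself, which removes a ring carbonyl and shortens the ring while adding a methylene link to the amide-type nitrogen.

For compound 3 the expected step is a 1.5-fold higher number from compound 2 to compound 3 (0.17 log units; within the scatter), a small loss that may well fall within the scatter. Compound 3 is estimated at 60 nM in this assay, with a range from 20 nM to 180 nM.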

Compound 3, half-maximal inhibitory concentration: 74 nM
The estimate for compound 3 lay 1.2-fold (0.09 log units) below the measured number, and the stated range covers the measured number.
By their numbers in this assay, from the lowest: compounds 2, 3 and 1 (each within the scatter of the next, the first and the last beyond it).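

In this assay, (1-methylpyrrolidin-3-yl)methyl in place of 1-methyl-2-oxopiperidin-4-yl on the amide-type nitrogen gives a 1.8-fold higher number from compound 2 to compound 3 (0.26 log units; within the scatter), the first single-place step available in the series. This substituent can therefore be exchanged without a change that exceeds the scatter, even though the ring carbonyl is lost, the six-membered ring gives way to a five-membered ring and a methylene link enters, so the ring carbonyl of compound 2 is not needed for compound 3 to read 74 nM. No supporting data are available to explain how these two substituents compare.

This one step changes the ring size, the carbonyl and the link together, so their separate contributions remain unresolved; 1-methylpiperidin-4-yl would remove only the carbonyl from the substituent of compound 2, while 1-methylpyrrolidin-3-yl attached directly to the amide-type nitrogen would remove only the methylene link from that of compound 3. Also open, on these data alone, is how far this position extends beyond these two tertiary-amine and lactam rings, for example to a longer chain ending in a primary amine or a carboxylic acid.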